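From Compound 3 to Compound 4: An Untested Aryl Swap

The source may report more compounds than this note shows. Statements on the series, on what has been measured and on what is new or still open speak of the compounds shown alone.

In a functional assay on MCF7 cells (Homo sapiens) for cytotoxicity, read by MTT assay, with a stated time of 24 h (a higher number here means a weaker inhibitor, a lower number a stronger inhibitor), compound 1 `CCc1cc(Br)ccc1Nc1ncnc2cc(OC)c(OCCCSc3nc4ccccc4s3)cc12` gives 5870 nM, compound 2 `CCc1cc(Br)ccc1Nc1ncnc2cc(OC)c(OCCCSc3nc4ccccc4o3)cc12` gives 17300 nM and compound 3 `CCCCc1nc(Cl)c(C=O)n1CCCOc1cc2c(Nc3ccc(Br)cc3CC)ncnc2cc1OC` gives 6560 nM. Compound 3 thus stands level with one of its two neighbours and apart from the other: the data show a 1.1-fold higher number from compound 1 to compound 3 (0.05 log units; within the scatter), and also a 2.6-fold lower number from compound 2 to compound 3 (0.42 log units; beyond the scatter).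

Compound 4 `C#Cc1cccc(Nc2ncnc3cc(OC)c(OCCCn4c(CCCC)nc(Cl)c4C=O)cc23)c1` carries 3-ethynylphenyl in place of 4-bromo-2-ethylphenyl on a nitrogen on an aromatic ring. Within the data shown here, no measured step touches this group, since all three measured compounds carry 4-bromo-2-ethylphenyl. The measured steps change a different part of the molecule, and the largest of them is a 2.9-fold higher number from compound 1 to compound 2 (0.47 log units; beyond the scatter). That step offers only a rough sense of scale and no direction for the new change. In this assay, therefore, no shift beyond the scatter is expected, although the uncertainty is wide. The expected outcome is a 1.0-fold lower number from compound 3 to compound 4 (0.00 log units; within the scatter). For compound 4 the estimated value is 6500 nM, with an expected range from 2500 nM to 17000 nM.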

Compound 4, half-maximal inhibitory concentration: 10100 nM
Estimate against measurement, compound 4: 1.6-fold (0.19 log units) below, within the range that was stated.
By their numbers in this assay, from the lowest: compounds 1, 3, 4 and 2 (each within the scatter of the next, the first and the last beyond it).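

Among these compounds, compound 4 gives the first reading at this place, on a nitrogen on an aromatic ring: in this assay, 3-ethynylphenyl in place of 4-bromo-2-ethylphenyl gives a 1.5-fold higher number from compound 3 to compound 4 (0.19 log units; within the scatter). For this pair, which shares the 2-butyl-4-chloro-5-formyl-1H-imidazol-1-yl group, the exchange therefore cannot be told from the scatter, even though the bromine and the ethyl group leave and a triple bond enters. Nothing in hand bears on why the two aryl groups read alike.

On these data alone, because the bromine, the ethyl group and the ethynyl group change in a single step, their separate contributions remain open, as does whether 3-ethynylphenyl would read the same with the (1,3-benzothiazol-2-yl)sulfanyl or (1,3-benzoxazol-2-yl)sulfanyl group. As far as these compounds go, it is also open how this assay would respond to an unsubstituted phenyl or a phenyl carrying a carboxylic acid on that nitrogen.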